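A few compounds are considered here, and "the series" means these few. Any claim that something is new, unique, unknown or untested is made for them only; others in the source may bear on it.

In a functional assay on HeLa cells (Homo sapiens) for cytotoxicity, read by ELISA, with a stated time of 2 days (on this read-out higher numbers stand for weaker inhibition and lower numbers for stronger inhibition), compound 1 `Oc1cccc(-c2cc(-c3ccccc3)cc(-c3ccco3)n2)c1` gives 9430 nM and compound 2 `Oc1cccc(-c2cc(-c3ccccc3)cc(-c3ccncc3)n2)c1` gives 28100 nM as the higher of the two numbers, which marks compound 2 as the weaker inhibitor. Compound 3 `Oc1cccc(-c2cc(-c3ccccc3)cc(-c3cccc(O)c3)n2)c1` carries 3-hydroxyphenyl in place of pyridin-4-yl next to the ring nitrogen (3-hydroxyphenyl in place of pyridin-4-yl on an aromatic carbon). Among the compounds with values here, only one measured step touches this place (a 3.0-fold higher number from compound 1 to compound 2 (0.47 log units; beyond the scatter)) with pyridin-4-yl in place of furan-2-yl, and it runs toward weaker inhibition. With pyridin-4-yl leaving, a step of similar size toward stronger inhibition is expected (a 2.8-fold lower number from compound 2 to compound 3 (0.45 log units; beyond the scatter)). Compound 3 is estimated at 10000 nM with an expected range from 3000 nM to 30000 nM in this read-out.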

Compound 3, half-maximal inhibitory concentration: 13000 nM
Beside the measured number, compound 3's estimate is 1.3-fold (0.11 log units) below it; measured number inside the range.
By their numbers in this assay, from the lowest: compounds 1 and 3 (each within the scatter of the next); then compound 2.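

In this assay, the position next to the ring nitrogen gains from losing pyridin-4-yl with a second replacement too: 3-hydroxyphenyl gives a 2.2-fold lower number from compound 2 to compound 3 (0.33 log units; beyond the scatter) and so moves toward stronger inhibition. Against furan-2-yl, the same group gives a 1.4-fold higher number from compound 1 to compound 3 (0.14 log units; within the scatter) and so cannot be told apart from it, which leaves pyridin-4-yl as the one group of the three that stands apart. No measurement shown here explains this difference. Open, as far as these compounds go, is how an amine or a carboxylic acid at this position would compare, and whether 3-hydroxyphenyl behaves the same with the phenyl group changed.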